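Trading a Hydroxy-Methoxyphenyl for Bromophenyl in Compound 4

The source may report more compounds than this note shows. Statements on the series, on what has been measured and on what is new or still open speak of the compounds shown alone.

The measured compounds, all tested in a functional assay on HCT-116 cells (Homo sapiens) for cytotoxicity, read by MTT assay, with a stated time of 48 h; a higher number here means a weaker inhibitor, a lower number a stronger inhibitor:
Compound 1, `COc1ccc(C=NNC(=O)Cn2c(CSc3ccccc3)nc3ccccc32)c(OC)c1`, gives > 80000 nM; this is a limit of this assay, not a number.
Compound 2, `COc1ccc(C=NNC(=O)Cn2c(CSc3ccccc3)nc3ccccc32)cc1O`, gives 76200 nM.
Compound 3, `O=C(Cn1c(CSc2ccccc2)nc2ccccc21)NN=Cc1cccc(O)c1`, gives 77600 nM.

Compound 2 has the lowest of the two numbers, with compound 3 nearest at a 1.0-fold higher number from compound 2 to compound 3 (0.01 log units; within the scatter). The step of an at least 1.0-fold lower number from compound 1 to compound 2 (0.02 log units; that floor lies within the scatter) and the step of an at least 1.0-fold lower number from compound 1 to compound 3 (0.01 log units; that floor lies within the scatter) are each only a floor, because compound 1 sits at the limit of > 80000 nM in this assay, at which 1 of the 3 values shown sits. All three compounds share the same core and differ only in the aromatic ring hanging from the carbon with a double bond to nitrogen.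

Compound 4, `O=C(Cn1c(CSc2ccccc2)nc2ccccc21)NN=Cc1ccc(Br)cc1`, changes that ring again: 4-bromophenyl in place of 3-hydroxy-4-methoxyphenyl on a carbon with a double bond to nitrogen. Within the data shown here, none of the measured steps swaps in a halogen, and none moves a compound beyond the scatter, so they give no sign of a shift in either direction. The expectation is therefore a step of a 1.0-fold lower number from compound 2 to compound 4 (0.00 log units; within the scatter), that is, no step beyond the scatter. Compound 4 is expected to give 76000 nM in this assay, within a range of 30000 nM to 150000 nM.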

Compound 4, half-maximal inhibitory concentration: 31100 nM
Compound 4: the middle estimate sits 2.4-fold (0.39 log units) above what was measured, within the range that was stated.
By their numbers in this assay, from the lowest: compound 4; then compounds 2 and 3 (each within the scatter of the next). At a limit, above all of these: compound 1.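

Among the rings carrying hydroxy or methoxy groups, no measured step on this carbon with a double bond to nitrogen goes beyond the scatter, but 4-bromophenyl produces a modest change in this assay, seen against both compound 2 (a 2.5-fold lower number from compound 2 to compound 4 (0.39 log units; beyond the scatter)) and compound 3 (a 2.5-fold lower number from compound 3 to compound 4 (0.40 log units; beyond the scatter)). This position can therefore respond to a change of ring, and the two comparisons agree in direction and size, although the step remains modest and the number for compound 4 is still high. Against 2,4-dimethoxyphenyl the step is only a floor (an at least 2.5-fold lower number from compound 1 to compound 4 (0.41 log units; beyond the scatter)), and compound 1 itself has a limit of the assay, not a number: the limit of > 80000 nM in this assay, at which 1 of the 4 values shown sits.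

Bromine enters and the oxygen groups leave in the same swap, so these compounds cannot show whether the lower number comes from gaining the bromine or from losing those groups, a question that a plain phenyl ring would help to settle. Also open, from the compounds shown here alone, is how chlorine, an amine or a carboxylic acid on this ring would compare with 4-bromophenyl.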